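This account rests on a few compounds, and the source may have more. Where it says the series, first, only, none or still open, it means among the compounds named here.

Of the compounds shown here, three sharing one core have been measured in a functional assay on the whole organism (heart) with Rattus norvegicus as the target; a lower number here means that less compound is needed, a higher number that more compound is needed for the effect. Compound 1 `CC(=O)/C(=C\c1ccccc1)Oc1ccccc1OCCCN1CCN(C)CC1` gives 2.5 mg/kg, compound 2 `CC(=O)/C(=C\c1ccccc1)Oc1ccccc1OCC(C)N(C)C` gives 0.9 mg/kg, and compound 3 `CC(=O)/C(=C\c1ccccc1)Oc1ccccc1OCCCN1CCCCC1` gives 0.2 mg/kg, the lowest number of the three. Compound 4 `CC(=O)/C(=C\c1ccccc1)Oc1ccccc1OCC(O)CN1CCN(C)CC1` departs from compound 3 in one place: 1-hydroxy-2-(4-methylpiperazin-1-yl)ethyl in place of 2-(piperidin-1-yl)ethyl on a saturated chain carbon bound to an oxygen on an aromatic ring.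

The most relevant measured step is a 13-fold lower number from compound 1 to compound 3 (1.10 log units; beyond the scatter), where piperidin-1-yl replaces 4-methylpiperazin-1-yl. Compound 4 carries 4-methylpiperazin-1-yl, so a reversal of much of that large step is expected. The steps of a 2.8-fold lower number from compound 1 to compound 2 (0.44 log units; beyond the scatter) and a 4.5-fold lower number from compound 2 to compound 3 (0.65 log units; beyond the scatter) are modest and bear on it less directly, as both involve the 1-(dimethylamino)ethyl group of compound 2. Within the data shown here, no measured compound carries the 1-hydroxy group, so its contribution is unknown, and the range is kept wide.

In this assay, the expected change is a 13-fold higher number from compound 3 to compound 4 (1.10 log units; beyond the scatter), a large step towards a higher number. The estimate for compound 4 is 2.5 mg/kg, with an expected range from 0.7 mg/kg to 9 mg/kg.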

Compound 4, dose for half-maximal effect: 7.5 mg/kg
Compound 4: middle estimate off by 3.0-fold (0.48 log units), on the low side, and the stated range covers the measured number.
By their numbers in this assay, from the lowest: compound 3; then compound 2; then compound 1; then compound 4.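

In this assay, the pair that isolates the hydroxy shows a 3.0-fold higher number from compound 1 to compound 4 (0.48 log units; beyond the scatter), so hydroxy in place of hydrogen on a saturated chain carbon bound to two saturated chain carbons raises the number with 4-methylpiperazin-1-yl held constant. The full exchange for 2-(piperidin-1-yl)ethyl gives a 38-fold higher number from compound 3 to compound 4 (1.57 log units; beyond the scatter), and the exchange for the 1-(dimethylamino)ethyl group gives an 8.3-fold higher number from compound 2 to compound 4 (0.92 log units; beyond the scatter), leaving compound 4 with the highest number of the four. No measurement at hand accounts for the effect of the hydroxy.

The compounds shown leave open whether the hydroxy would shift the number to the same extent on a chain ending in piperidin-1-yl. They also leave open how a methoxy group in its place, or a morpholin-4-yl ring in place of 4-methylpiperazin-1-yl, would read in this assay.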